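The source may report more compounds than this note shows. Statements on the series, on what has been measured and on what is new or still open speak of the compounds shown alone.

Measured compounds:
- Compound 1 `N/C(=N\NC(=S)N1CCOCC1)c1ccccn1` — in a functional assay on A-431 cells (Homo sapiens) for cytotoxicity, read by MTT assay, with a stated time of 72 h, tested at 30 uM (a lower number here means less inhibition of growth, a higher number more inhibition of growth at the concentration tested), compound 1 gives 78.8%
- Compound 2 `Cc1cccc(/C(N)=N/NC(=S)N2CCSCC2)n1` — in this assay compound 2 gives 64.5%

Of the two numbers, compound 2 gives the lower one, and compound 1 stands higher by a margin beyond the usual scatter; the two differ in more than one place, so their values are only set side by side here. Compound 3 `Cc1cccc(/C(N)=N/NC(=S)N2CCOCC2)n1` has not yet been tested in this assay. It differs from compound 2 in one way: morpholin-4-yl in place of thiomorpholin-4-yl on a thiocarbonyl carbon. Among the compounds with values here, no pair of measured compounds shows this change alone, so its effect is not known from the data. Compound 1 carries the same morpholin-4-yl group and gives the higher number, which suggests a modest upward step, though one that may fall within the scatter. Compound 3 is expected to give 70%, within 55% to 85%, an estimated step of a number 5.5 percentage points higher from compound 2 to compound 3 (within the scatter).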

Compound 3, percent growth inhibition at one concentration: 80%
For compound 3 the middle estimate is 10 percentage points below the measured one, and the stated range covers the measured number.
By their numbers in this assay, from the lowest: compound 2; then compounds 1 and 3 (each within the scatter of the next).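

In this assay, within the data shown here, the exchange of thiomorpholin-4-yl for morpholin-4-yl on a thiocarbonyl carbon gives a number 15.5 percentage points higher from compound 2 to compound 3 (beyond the scatter) and is thus the first reading of this change alone. Methyl in place of hydrogen on an aromatic carbon gives a number 1.2 percentage points higher from compound 1 to compound 3 (within the scatter) and so separates compound 1 from compound 3 by no more than the scatter, leaving the ring exchange as the only one of these two single changes that lies beyond it. Nothing available explains this step.

The compounds shown leave open how piperidin-1-yl or an open-chain dimethylamino group on the same thiocarbonyl carbon would compare with morpholin-4-yl. They also leave open whether ethyl or a longer chain in place of methyl on the aromatic carbon would stay within the scatter.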